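Urea and amide variations on a shared core against PAK 1

The source may report more compounds than this note shows. Statements on the series, on what has been measured and on what is new or still open speak of the compounds shown alone.

Measured so far:
compound 1 `O=C(NC1CCN(c2ncnc3[nH]ncc23)CC1)c1cccc(Cl)c1Cl` gives 4170 nM
compound 2 `Cc1ccc(NC(=O)NC2CCN(c3ncnc4[nH]ncc34)CC2)cc1` gives 4710 nM
compound 3 `O=C(Nc1cccc(Cl)c1)NC1CCN(c2ncnc3[nH]ncc23)CC1` gives 1240 nM

All three share the same core and were tested in an assay on isolated protein for inhibition of serine/threonine-protein kinase PAK 1 (Homo sapiens), read by ADP-Glo, with a stated time of 40 min; on this read-out higher numbers stand for weaker inhibition and lower numbers for stronger inhibition. Compound 3 stands lowest of the three numbers: the step of a 3.4-fold lower number from compound 1 to compound 3 (0.53 log units; beyond the scatter) and the step of a 3.8-fold lower number from compound 2 to compound 3 (0.58 log units; beyond the scatter) are both modest but beyond the scatter, whereas a 1.1-fold higher number from compound 1 to compound 2 (0.05 log units; within the scatter) is within it. So the 3-chlorophenyl urea of compound 3 separates from the amide of compound 1 and from the 4-methylphenyl urea of compound 2, but not by much.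

Compound 4 `O=C(Nc1ccc(F)cc1F)NC1CCN(c2ncnc3[nH]ncc23)CC1` is not yet measured in this assay. Its difference from compound 3 is 2,4-difluorophenyl in place of 3-chlorophenyl on an amide-type nitrogen. The nearest comparison is the step from compound 2 to compound 3, which also changes only the aryl group on the urea nitrogen; it was modest. For the measured compounds named here, no measured pair exchanges one halogenated phenyl for another, so the direction of the present change cannot be read from the data. A step of similar modest size, in either direction, is the most that is expected; a number no further from compound 3 than within the scatter is also quite possible.

For compound 4 the expected step in this assay is a 1.6-fold higher number from compound 3 to compound 4 (0.21 log units; within the scatter). Compound 4 is therefore estimated at 2000 nM, with a range from 700 nM to 6000 nM.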

Compound 4, half-maximal inhibitory concentration: 1140 nM
Beside the measured number, compound 4's estimate is 1.8-fold (0.24 log units) above it; the range from low to high includes it.
By their numbers in this assay, from the lowest: compounds 4 and 3 (each within the scatter of the next); then compounds 1 and 2 (each within the scatter of the next).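

On the amide-type nitrogen, exchanging 3-chlorophenyl for 2,4-difluorophenyl leaves the result in this assay within the scatter (a 1.1-fold lower number from compound 3 to compound 4 (0.04 log units; within the scatter)), so this change of halogen and halogen count does not separate the two ureas. Compound 4 stands apart from the other two compounds much as compound 3 does, both steps being modest but beyond the scatter (a 4.1-fold lower number from compound 2 to compound 4 (0.62 log units; beyond the scatter); a 3.7-fold lower number from compound 1 to compound 4 (0.56 log units; beyond the scatter)), so that separation now rests on two halogenated phenyl ureas and not on compound 3 alone. The series offers no independent evidence that would explain this result.

The step between compound 1 and compound 4 changes the aryl group and the link to the carbonyl carbon together, so a urea carrying 2,3-dichlorophenyl would be needed to separate the two changes. Going by these compounds, it also remains open whether this nitrogen accepts groups other than a substituted phenyl, such as a pyridyl ring, a benzyl group, or a phenyl ring carrying an amine or a carboxylic acid.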